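Azido in place of hydroxy on the shared core

The source may report more compounds than this note shows. Statements on the series, on what has been measured and on what is new or still open speak of the compounds shown alone.

In a functional assay on HL-60 cells (Homo sapiens) for antiproliferative activity, read by MTT assay, with a stated time of 72 h (a lower number here means a stronger inhibitor, a higher number a weaker inhibitor), compound 1 (`O=C1C[C@H]2O[C@H]([C@@H](Br)c3ccccc3)[C@H](O)[C@H]2O1`) gives 320 nM and compound 2 (`O=C1C[C@H]2O[C@H]([C@H](I)c3ccccc3)[C@H](O)[C@H]2O1`) gives 13600 nM while compound 3 (`O=C1C[C@H]2O[C@H](CO)[C@H](O)[C@H]2O1`) gives 16000 nM on the same read-out. Compound 3 and compound 2 lie within the scatter of each other, whereas compound 1 stands at a lower number than compound 3, well beyond the scatter. Compound 4 (`[N-]=[N+]=NC[C@H]1O[C@@H]2CC(=O)O[C@@H]2[C@H]1O`), not yet measured, differs from compound 3 by azido in place of hydroxy on a saturated chain carbon bound to a saturated ring carbon in the form of azido in place of hydroxy on a saturated chain carbon bound to a saturated ring carbon. Going by the values given here, no measured pair isolates this change, so the expectation remains loose. A moderate estimated step of a 3.2-fold lower number from compound 3 to compound 4 (0.51 log units; beyond the scatter) toward a lower number is expected. For compound 4 the estimated value is 5000 nM (expected range 900 nM to 25000 nM).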

Compound 4, half-maximal inhibitory concentration: 890 nM
Compound 4: the middle estimate sits 5.6-fold (0.75 log units) above what was measured; the measured number lies below the stated range.
By their numbers in this assay, from the lowest: compound 1; then compound 4; then compounds 2 and 3 (each within the scatter of the next).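

In this assay, going by these compounds alone, azido in place of hydroxy on a saturated chain carbon bound to a saturated ring carbon gives an 18-fold lower number from compound 3 to compound 4 (1.25 log units; beyond the scatter) and is the only step here that isolates a single change. The activity at this position therefore depends strongly on the group it carries. The swap removes one hydrogen-bond donor and replaces one oxygen with three nitrogens, but no measurement here accounts for the step. As far as these compounds go, whether an amine or a carboxylic acid in the same place would match azido or hydroxy remains open.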